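A few compounds are considered here, and "the series" means these few. Any claim that something is new, unique, unknown or untested is made for them only; others in the source may bear on it.

Compound 2 `C=C(C(=O)Nc1cc(Nc2nccc(-c3cn(C)c4ccccc34)n2)c(OC)cc1N(C)CCN(C)C)C(F)(F)F` gives the highest number of the three in a functional assay on A-431 cells (Homo sapiens) for antiproliferative activity, read by sulforhodamine B assay, with a stated time of 72 h (on this read-out higher numbers stand for weaker inhibition and lower numbers for stronger inhibition), at 11200 nM. Compound 1 `C=C(C)C(=O)Nc1cc(Nc2nccc(-c3cn(C)c4ccccc34)n2)c(OC)cc1N(C)CCN(C)C` gives 5340 nM, and compound 3 `C=C(Br)C(=O)Nc1cc(Nc2nccc(-c3cn(C)c4ccccc34)n2)c(OC)cc1N(C)CCN(C)C` gives 1060 nM. Compound 4 `C=C(Cl)C(=O)Nc1cc(Nc2nccc(-c3cn(C)c4ccccc34)n2)c(OC)cc1N(C)CCN(C)C` differs from compound 2 in one place: chloro in place of trifluoromethyl on a double-bonded chain carbon bound to a carbonyl carbon. Going by the values given here, two measured steps bear on this change. First, an 11-fold lower number from compound 2 to compound 3 (1.02 log units; beyond the scatter), and second, a 5.0-fold lower number from compound 1 to compound 3 (0.70 log units; beyond the scatter), both with bromo entering at the same place; by contrast, a 2.1-fold higher number from compound 1 to compound 2 (0.32 log units; beyond the scatter). Treating chloro as bromo was treated, a large fall in number is expected, though it may not reach the full size of the bromo step. Compound 4 is therefore estimated at 1500 nM in this assay, within 600 nM to 4000 nM, which would mean a 7.5-fold lower number from compound 2 to compound 4 (0.87 log units; beyond the scatter).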

Compound 4, half-maximal inhibitory concentration: 1550 nM
Beside the measured number, compound 4's estimate is 1.0-fold (0.01 log units) below it, and the stated range covers the measured number.
By their numbers in this assay, from the lowest: compounds 3 and 4 (each within the scatter of the next); then compound 1; then compound 2.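

In this assay, going by these compounds alone, chloro on a double-bonded chain carbon bound to a carbonyl carbon gives a 7.2-fold lower number from compound 2 to compound 4 (0.86 log units; beyond the scatter) and also a 3.4-fold lower number from compound 1 to compound 4 (0.54 log units; beyond the scatter) so bromo is not the only group here with a lower number than both trifluoromethyl and methyl. Chloro and bromo cannot be told apart at this place, since a 1.5-fold higher number from compound 3 to compound 4 (0.17 log units; within the scatter) lies within the scatter. Nothing measured here explains these differences. Whether fluoro, iodo or plain hydrogen at this place would match chloro and bromo remains open, and a dimethylaminomethyl group is equally untested among the compounds shown.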